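The source may hold more compounds than are shown below. What is called first, only, known or untested is meant among the compounds shown, and "the series" means these compounds.

Of the compounds shown here, three built on a shared core have so far been tested in a functional assay on the whole organism (artery, strain albino) with Rattus norvegicus as the target, with a stated time of 120 min, at a dose of 10 mg/kg by the oral route; a lower number here means less inhibition, a higher number more inhibition at the dose given (going by the name of the read-out). Compound 1 `COc1ccc(C2N=C(SCc3ccccc3)NC(C)=C2C(=O)Nc2ccc(F)cc2)cc1OC` gives 8.8%. Compound 2 `COc1ccc(C2N=C(SCc3ccc(Cl)cc3)NC(C)=C2C(=O)Nc2ccc(F)cc2)cc1OC`, which carries a chloro on its benzyl group, gives 15.5%. Compound 3 `CC1=C(C(=O)Nc2ccc(F)cc2)C(c2ccc([N+](=O)[O-])cc2)N=C(SCc2ccccc2)N1` gives 18%. The largest of the three numbers belongs to compound 3, yet its gaps to compound 2 and to compound 1 both lie within the scatter, so the three cannot be ranked against one another.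

Compound 4 `CC1=C(C(=O)Nc2ccc(F)cc2)C(c2ccc([N+](=O)[O-])cc2)N=C(SCc2ccc(F)cc2)N1` differs from compound 3 in one place: fluoro in place of hydrogen on an aromatic carbon. The closest guide is the step of a number 6.7 percentage points higher from compound 1 to compound 2 (within the scatter), in which a halogen also entered an aromatic carbon of the benzyl group; that step stayed within the scatter. The other step on record, a number 9.2 percentage points higher from compound 1 to compound 3 (within the scatter), altered a different part of the molecule and likewise stayed within the scatter. Nothing among these numbers points to a change beyond the scatter for a fluoro entering in the same manner, so the expected step of a number 2 percentage points higher from compound 3 to compound 4 (within the scatter) is small and of no settled direction. Compound 4 is therefore estimated to give 20%, with a likely range from 8% to 32%.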

Compound 4, a percentage reported as inhibition, in the whole organism at one dose (the size of the read-out at that dose, not a potency): 17%
Beside the measured number, compound 4's estimate is 3 percentage points above it; low and high end bracket the measured number.
By their numbers in this assay, from the lowest: compounds 1, 2, 4 and 3 (each within the scatter of the next).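

In this assay, turning the benzyl group into a 4-fluorobenzyl group gives a number 1 percentage points lower from compound 3 to compound 4 (within the scatter), so at this position the fluoro produces no change that can be told apart from repeat-to-repeat variation. Together with a number 6.7 percentage points higher from compound 1 to compound 2 (within the scatter), this means that a halogen on the benzyl group has now been seen on two versions of the shared core, a chloro on the one with 3,4-dimethoxyphenyl and a fluoro on the one with 4-nitrophenyl, and neither step leaves the scatter. Nothing available speaks to what lies behind this result.

On these data alone, these two steps involve only single halogen atoms on the benzyl group, so it remains open whether a very different group on that same aromatic carbon, such as an amine or a carboxylic acid, would produce a step beyond the scatter. It is also open whether a longer chain in place of the benzyl group would do so, since no step among these compounds yet shows a part of the molecule that clearly moves this read-out.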